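Sulfur-linked ring swap: compound 1 to compound 3

The source may report more compounds than this note shows. Statements on the series, on what has been measured and on what is new or still open speak of the compounds shown alone.

Going by the values given here, in a functional assay on HepG2 cells (Homo sapiens) for antiproliferative activity, read by MTT assay, with a stated time of 48 h (on this read-out higher numbers stand for weaker inhibition and lower numbers for stronger inhibition), two compounds have numbers so far. Compound 1 `COc1ccc(CN(C(=O)Cn2cc(CSc3nc4ccccc4s3)nn2)c2cc(OC)c(OC)c(OC)c2)cc1` gives 49200 nM, the higher of the two numbers and so the weaker inhibition. Compound 2 `COc1ccc(CN(C(=O)Cn2cc(CSc3nnc(-c4ccccc4)c(-c4ccccc4)n3)nn2)c2cc(OC)c(OC)c(OC)c2)cc1` gives 21800 nM, a lower number by a gap beyond the usual scatter. Compound 3 `COc1ccc(CN(C(=O)Cn2cc(CSc3nnnn3C)nn2)c2cc(OC)c(OC)c(OC)c2)cc1` has no number yet. Its difference from compound 1 is 1-methyl-1H-tetrazol-5-yl in place of 1,3-benzothiazol-2-yl on a sulfur, with the rest of the structure unchanged. Among the compounds with values here, no measured pair isolates a change at this place, so the data do not fix a direction. Within the data shown here, the expectation rests only on the span of the two known numbers, with compound 2 at 21800 nM and compound 1 at 49200 nM. No step beyond the scatter is expected in this assay, and the expected move is a 1.3-fold lower number from compound 1 to compound 3 (0.11 log units; within the scatter). For compound 3 the estimate is 38000 nM, with an expected range of 14000 nM to 100000 nM.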

Compound 3, half-maximal inhibitory concentration: 28300 nM
Estimate against measurement, compound 3: 1.3-fold (0.13 log units) above; the measured number falls inside the stated range.
By their numbers in this assay, from the lowest: compounds 2, 3 and 1 (each within the scatter of the next, the first and the last beyond it).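

In this assay, going by these compounds alone, this is the first pair that isolates a change on the sulfur whose other neighbour is a saturated chain carbon: 1-methyl-1H-tetrazol-5-yl in place of 1,3-benzothiazol-2-yl gives a 1.7-fold lower number from compound 1 to compound 3 (0.24 log units; within the scatter). The swap exchanges a five-membered aromatic ring with 2 hetero atoms plus a six-membered aromatic ring of carbon only for a single five-membered aromatic ring with 4 hetero atoms, and the read-out shows no step beyond the usual scatter, so the six-membered carbon ring is not needed to hold the number at this level in this pair. No measurement in hand bears on what lies behind this result.

A single pair leaves open whether any group at this place can produce a step beyond the scatter, for example a carboxylic acid, a primary amine or a longer alkyl chain on the sulfur. It also leaves open whether the sulfur itself matters, since a compound with an oxygen or a methylene linking the same 1-methyl-1H-tetrazol-5-yl ring to the shared core would be needed to separate the linker from the ring.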